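Benzyl variation: from compound 3 to compound 4

A few compounds are considered here, and "the series" means these few. Any claim that something is new, unique, unknown or untested is made for them only; others in the source may bear on it.

Values in a functional assay on A549 cells (Homo sapiens) for inhibition, read by MTT assay, with a stated time of 48 h; a lower number here means a stronger inhibitor, a higher number a weaker inhibitor:
- compound 1 `O=C1N/C(=N\Cc2ccccc2)S/C1=C1/CCNC(=O)c2[nH]ccc21` gives 26900 nM
- compound 2 `COc1ccc(C/N=C2\NC(=O)/C(=C3\CCNC(=O)c4[nH]ccc43)S2)cc1` gives 18300 nM
- compound 3 `O=C1N/C(=N\Cc2cccc(Cl)c2)S/C1=C1/CCNC(=O)c2[nH]ccc21` gives 35200 nM

Compound 3 stands within the scatter of the other two, with a 1.3-fold higher number from compound 1 to compound 3 (0.12 log units; within the scatter) and a 1.9-fold higher number from compound 2 to compound 3 (0.28 log units; within the scatter). Next comes compound 4 `Cc1ccc(C/N=C2\NC(=O)/C(=C3\CCNC(=O)c4[nH]ccc43)S2)cc1`, which carries 4-methylphenyl in place of 3-chlorophenyl on a saturated chain carbon bound to a double-bonded nitrogen. Related changes gave a 1.5-fold lower number from compound 1 to compound 2 (0.17 log units; within the scatter) with methoxy in place of hydrogen, alongside the two steps above. None left the scatter, so no step beyond it is expected in this assay. The estimate implies a 1.5-fold lower number from compound 3 to compound 4 (0.17 log units; within the scatter). Compound 4 is estimated at 24000 nM, with an expected range from 13000 nM to 42000 nM.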

Compound 4, half-maximal inhibitory concentration: 9080 nM
Compound 4: the middle estimate sits 2.6-fold (0.42 log units) above what was measured; measured number below the stated range.
By their numbers in this assay, from the lowest: compounds 4, 2, 1 and 3 (each within the scatter of the next, the first and the last beyond it).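

In this assay, the place on a saturated chain carbon bound to a double-bonded nitrogen now shows steps beyond the scatter, with 4-methylbenzyl giving a 3.9-fold lower number from compound 3 to compound 4 (0.59 log units; beyond the scatter) and a 3.0-fold lower number from compound 1 to compound 4 (0.47 log units; beyond the scatter), both modest, whereas all earlier steps stayed within it. The methyl and methoxy groups remain unseparated, with a 2.0-fold lower number from compound 2 to compound 4 (0.30 log units; within the scatter) within the scatter. No evidence on the series bears on these steps.

As far as these compounds go, what an amine or a carboxylic acid on the phenyl ring, or a longer chain in place of the benzyl group, would give in this assay remains open.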